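A few compounds are considered here, and "the series" means these few. Any claim that something is new, unique, unknown or untested is made for them only; others in the source may bear on it.

In a functional assay on RXF 393 cells (Homo sapiens) for inhibition, read by sulforhodamine B assay, with a stated time of 48 h (on this read-out higher numbers stand for lower toxicity in this test and lower numbers for higher toxicity in this test), compound 1 `Cc1ccc(C2=NN(c3ccc(S(C)(=O)=O)cc3)C(=O)CC2)cc1` gives > 100000 nM, which is a limit of the assay. Compound 2 `Cc1cc(O)ccc1C1=NN(c2ccc(S(C)(=O)=O)cc2)C(=O)CC1` gives > 100000 nM, also only a limit, so it has no numerical position in the series. The data so far consist of the limit of > 100000 nM in this assay, at which 2 of the 2 values shown sit. Among the measured compounds shown here, the one measured step is a step that the two limits leave unreadable from compound 1 to compound 2, and it offers no size to carry forward.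

The next change leads to compound 3 `CCc1ccc(C2=NN(c3ccc(S(C)(=O)=O)cc3)C(=O)CC2)cc1`, with 4-ethylphenyl in place of 4-hydroxy-2-methylphenyl on a carbon with a double bond to nitrogen.

With no readable step to draw on, and with compound 2 at > 100000 nM, no shift beyond the scatter is expected in this assay, in either direction. The expected a number no higher from compound 2 to compound 3 (the limit leaves the size open) is therefore small. For compound 3 the estimated value is 100000 nM, with an expected range of 50000 nM to 200000 nM, and another limit is the likeliest report.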

Compound 3, concentration lethal to 50% of the cells: > 100000 nM
Compound 3 gave a limit, no number; the forecaster's own chance of this, stated with the estimate: 85%; the middle value sits exactly at the limit.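

No step can be read among compound 1, compound 2 and compound 3, as each result is only a limit: the limit of > 100000 nM in this assay, at which 3 of the 3 values shown sit.

The compounds shown leave open whether any of these group changes on the shared core shifts the read-out in this assay, and in which direction.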